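This account rests on a few compounds, and the source may have more. Where it says the series, first, only, none or still open, it means among the compounds named here.

Compound 1 `COc1cc(-n2ncnc2-c2cccc(F)c2)cc(OC)c1OC` is examined in a functional assay on K562 cells (Homo sapiens) for antiproliferative activity, read by MTT assay, with a stated time of 72 h; a lower number here means a stronger inhibitor, a higher number a weaker inhibitor. In this assay compound 1 gives > 10000 nM, which is a limit of the assay rather than a number. Compound 2 `CCOc1cccc(-c2ncnn2-c2cc(OC)c(OC)c(OC)c2)c1` differs from compound 1 by ethoxy in place of fluoro on an aromatic carbon. In this assay compound 2 gives > 10000 nM, again a limit and not a number. Among the compounds with values here, the one measured step, a step that the two limits leave unreadable from compound 1 to compound 2, cannot be read, as both values sit at the limit of > 10000 nM in this assay, at which 2 of the 2 values shown sit. Compound 3 `COc1cc(-n2ncnc2-c2ccc(SC)cc2)cc(OC)c1OC` has not yet been measured; it differs from compound 1 by 4-(methylsulfanyl)phenyl in place of 3-fluorophenyl on an aromatic carbon. Within the data shown here, no measured step gives a readable size or direction for this kind of change, so nothing beyond the scatter can be predicted from the numbers in hand. Compound 3 is therefore expected to stay near the limit where compound 1 stands, a step estimated at a step that the limit leaves unreadable from compound 1 to compound 3. The estimate for compound 3 in this assay is 12000 nM, with a range from 3000 nM to 40000 nM.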

Compound 3, half-maximal inhibitory concentration: 340 nM
For compound 3 the middle estimate is 35-fold (1.55 log units) above the measured one; measured number below the stated range.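

In this assay, the group on this aromatic carbon of the five-membered aromatic ring proves able to move the result: 4-(methylsulfanyl)phenyl in place of 3-fluorophenyl gives an at least 29-fold lower number from compound 1 to compound 3 (1.46 log units; beyond the scatter). Within the data shown here, this is the first readable step, and it shows that the shared core can give a measured number and not only a limit. The earlier step cannot be read, as compound 1 and compound 2 both rest at a limit of the assay: the limit of > 10000 nM in this assay, at which 2 of the 3 values shown sit.

The change swaps the substituent and also its place on the phenyl ring, and the compounds shown do not separate the two; 4-fluorophenyl and 3-(methylsulfanyl)phenyl would bear on this. Also open, going by these compounds, is how a longer chain on the sulfur, as in 4-(ethylsulfanyl)phenyl, or an amine in its place would read.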